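This account rests on a few compounds, and the source may have more. Where it says the series, first, only, none or still open, it means among the compounds named here.

Of the compounds shown here, three have so far been measured in an ADME assay on microsomes from liver (Homo sapiens) for metabolic stability; a lower number here means that the compound disappears faster, a higher number that the compound lasts longer. Compound 1 `Cn1c(-c2ccccc2)cnc1NC(=O)c1ncc[nH]1` gives 1.47 h, the highest of the three numbers. Compound 2 `COc1ccc(-c2cnc(NC(=O)c3ccc(F)cc3)n2C)cc1` gives 0.983 h, a number within the scatter of compound 1. Compound 3 `O=C(Nc1ncc(-c2ccccc2)o1)c1ccc(F)cc1` gives 0.317 h, and its gap to compound 1 lies beyond the scatter. Compound 4 `Cn1c(-c2ccc(Cl)cc2)cnc1NC(=O)c1ncc[nH]1` has not been measured. It differs from compound 1 in a single place: chloro in place of hydrogen on an aromatic carbon. Put one bond further out, the change reads phenyl to 4-chlorophenyl. Within the data shown here, no measured pair here shows what such a change does in this assay, so a small step, upward or none beyond the scatter, is expected. Compound 4 is estimated at 1.8 h, with a range from 0.9 h to 3.6 h. The expected step is a 1.2-fold higher number from compound 1 to compound 4 (0.09 log units; within the scatter).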

Compound 4, half-life: > 4.25 h
Compound 4 gave a limit, no number; the forecaster's own chance of this, stated with the estimate: 5%; middle value at least 2.3-fold (0.37 log units) from the limit.
By their numbers in this assay, from the lowest: compound 3; then compounds 2 and 1 (each within the scatter of the next). At a limit, above all of these: compound 4.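

Chloro in place of hydrogen on this aromatic carbon is the first single change that can be read in this assay, and it gives an at least 2.8-fold higher number from compound 1 to compound 4 (0.46 log units; beyond the scatter). One added heavy atom at this position is therefore enough to move the number beyond the scatter. The reading for compound 4 is a limit and not a number: the limit of > 4.25 h in this assay, at which 1 of the 4 values shown sits.

As far as these compounds go, what an amine or a carboxylic acid would do at this place remains open. So does whether chloro gives a similar step on a different core.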